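Swapping a Small Saturated Ring for an Aromatic One

This account rests on a few compounds, and the source may have more. Where it says the series, first, only, none or still open, it means among the compounds named here.

Compound 1 `Cc1ccc(OCC(=O)N(Cc2cccs2)C2COC2)cc1` was tested in an assay on HEK293 cells for agonist activity at transient receptor potential cation channel subfamily M member 8 (Homo sapiens), read by fluorescence and calcium flux, with a stated time of 15 min (a higher number here means that more compound is needed for the effect, a lower number that less compound is needed), and gave 23000 nM, the highest number of the two compounds measured. Its nearest neighbour, compound 2 `CCN(Cc1cccs1)C(=O)COc1cccc(C)c1`, gives 97 nM, a gap that lies well beyond the scatter. Compound 3 `Cc1ccc(OCC(=O)N(Cc2cccs2)c2ncco2)cc1` has not yet been measured. It differs from compound 1 in one place: 1,3-oxazol-2-yl in place of oxetan-3-yl on an amide-type nitrogen. Within the data shown here, no measured pair shows this change, so the size of its effect is open; a modestly lower number seems the more likely outcome, and the expected step is a 2.9-fold lower number from compound 1 to compound 3 (0.46 log units; beyond the scatter). Compound 3 is therefore estimated at 8000 nM, within a range from 1500 nM to 40000 nM.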

Compound 3, half-maximal effective concentration: 0.3 nM
Beside the measured number, compound 3's estimate is 27000-fold (4.43 log units) above it; measured number below the stated range.
By their numbers in this assay, from the lowest: compound 3; then compound 2; then compound 1.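

On the amide-type nitrogen, the choice of ring has a very large effect: 1,3-oxazol-2-yl in place of oxetan-3-yl gives a 77000-fold lower number from compound 1 to compound 3 (4.88 log units; beyond the scatter) in this assay. This single position can therefore move the number across a very wide range. The change replaces a four-membered non-aromatic ring with a five-membered aromatic ring, but nothing available explains the size of this step.

Going by these compounds, it remains open whether the ring's aromatic character or its ring nitrogen matters more. A phenyl or 1,3-thiazol-2-yl group at this position could help separate the two.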